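From 3-bromophenyl to 4-iodophenyl

The compounds below may be only part of what the source reports. "The series", "measured", "known", "first", "only" and "open" are said of these compounds alone.

Compound 1 `COc1ccccc1Oc1c(N)nc(-c2cccc(C)c2)nc1OCCO`: 70900 nM
Compound 2 `COc1cccc(-c2nc(N)c(Oc3ccccc3OC)c(OCCO)n2)c1`: 30500 nM
Compound 3 `COc1ccccc1Oc1c(N)nc(-c2cccc(Br)c2)nc1OCCO`: 21900 nM

In a functional assay on B16 cells (Mus musculus) for cytotoxicity, read by CCK-8 assay, with a stated time of 24 h (on this read-out lower numbers stand for stronger inhibition and higher numbers for weaker inhibition), compound 3 gives 21900 nM, on a level with compound 2 and clearly under compound 1. Compound 4 `COc1ccccc1Oc1c(N)nc(-c2ccc(I)cc2)nc1OCCO` has 4-iodophenyl in place of 3-bromophenyl on an aromatic carbon. Two measured swaps on that phenyl bear on this change. Bromo in place of methyl gave a 3.2-fold lower number from compound 1 to compound 3 (0.51 log units; beyond the scatter), a modest step, and bromo in place of methoxy gave a 1.4-fold lower number from compound 2 to compound 3 (0.14 log units; within the scatter), which stays within the scatter. Among the measured compounds shown here, no measured compound carries a 4-iodophenyl, so only a small move is expected, slightly downward if anything. The expected change is a 1.2-fold lower number from compound 3 to compound 4 (0.09 log units; within the scatter). For compound 4 the estimated value is 18000 nM, with an expected range of 7000 nM to 45000 nM.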

Compound 4, half-maximal inhibitory concentration: 19600 nM
Compound 4: the middle estimate sits 1.1-fold (0.04 log units) below what was measured; low and high end bracket the measured number.
By their numbers in this assay, from the lowest: compounds 4, 3 and 2 (each within the scatter of the next); then compound 1.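

Swapping 3-bromophenyl for 4-iodophenyl gives a 1.1-fold lower number from compound 3 to compound 4 (0.05 log units; within the scatter) and so leaves the number level in this assay, and the comparison with 3-methoxyphenyl, a 1.6-fold lower number from compound 2 to compound 4 (0.19 log units; within the scatter), also stays within the scatter. Only the comparison with 3-methylphenyl, a 3.6-fold lower number from compound 1 to compound 4 (0.56 log units; beyond the scatter), stands clear of the scatter, so this position accepts a different halogen at a different place on the phenyl without a clear loss. Nothing available explains these numbers.

This swap changes the halogen and its place together, so the two cannot be told apart. Going by these compounds, how an amine or a carboxylic acid on this phenyl would read remains open.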